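A few compounds are considered here, and "the series" means these few. Any claim that something is new, unique, unknown or untested is made for them only; others in the source may bear on it.

Among the compounds with values here, in a functional assay on MOLT-4 cells (Homo sapiens) for antiproliferative activity (on this read-out lower numbers stand for stronger inhibition and higher numbers for weaker inhibition), compound 1 `Nc1nc(Cl)c2nnn([C@H]3CCC[C@H]3CO)c2n1` gives 75300 nM, the only actual number available so far. Compound 2 `Nc1nc(O)c2ncn([C@H]3CCC[C@H]3CO)c2n1` gives > 200000 nM, which is a limit of the assay and not a number. Compound 3 `Nc1nc(N)c2nnn([C@H]3CCC[C@H]3CO)c2n1`, still unmeasured, keeps the core of compound 1 and carries amino in place of chloro on an aromatic carbon. Within the data shown here, no measured step of this kind exists to lean on, so the expectation in this assay stays modest: a small weakening, about the size of the usual scatter, with the number moving upward toward the limit seen for compound 2. The expected change is a 1.5-fold higher number from compound 1 to compound 3 (0.16 log units; within the scatter). For compound 3 the estimated value is 110000 nM, with an expected range from 40000 nM to 250000 nM.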

Compound 3, half-maximal inhibitory concentration: 120000 nM
Estimate against measurement, compound 3: 1.1-fold (0.04 log units) below; measured number inside the range.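

In this assay, putting amino in place of chloro on this aromatic carbon, next to the ring nitrogen, gives a 1.6-fold higher number from compound 1 to compound 3 (0.20 log units; within the scatter). Within the data shown here, this is the first step that can be read at this position, and it shows that exchanging the chlorine for a nitrogen group with a hydrogen-bond donor and acceptor leaves the two compounds indistinguishable on this read-out. Compound 2 stands as a limit of the assay and not a number, which marks where the measurable scale ends: the limit of > 200000 nM in this assay, at which 1 of the 3 values shown sits.

From the compounds shown here alone, whether any group at this position could give a clearly lower number remains open, for example a methoxy group, a methylamine or a longer chain such as a butylamine. The compounds shown also cannot explain why this exchange makes no measurable difference.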